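Hydroxypyridine in place of fluorophenyl on the amide nitrogen

The source may hold more compounds than are shown below. What is called first, only, known or untested is meant among the compounds shown, and "the series" means these compounds.

In an ADME assay on Vero cells (Chlorocebus sabaeus) for cytotoxicity (a higher number here means that more compound is tolerated, a lower number that less compound is tolerated), compound 1 `O=C(Nc1ccccc1F)c1cccc2[nH]c(-c3cccnc3)nc12` gives 54.7 uM. Compound 2 `COc1ccc(-c2nc3c(C(=O)Nc4ccccc4F)cccc3[nH]2)cc1OC` gives 24.5 uM in this assay and stands lowest of the two numbers shown, with compound 1 the nearest at a gap beyond the scatter. Compound 3 `COc1ccc(-c2nc3c(C(=O)Nc4ncccc4O)cccc3[nH]2)cc1OC` has not yet been measured. It differs from compound 2 by 3-hydroxypyridin-2-yl in place of 2-fluorophenyl on an amide-type nitrogen. Among the compounds with values here, no step between two measured compounds covers this change, so nothing anchors it. The expected step in this assay is a 1.2-fold higher number from compound 2 to compound 3 (0.09 log units; within the scatter), which is none beyond the scatter. Compound 3 is estimated at 30 uM, within a range from 12 uM to 75 uM.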

Compound 3, half-maximal toxic concentration: 164 uM
Compound 3: the middle estimate sits 5.5-fold (0.74 log units) below what was measured; measured number above the stated range.
By their numbers in this assay, from the lowest: compound 2; then compound 1; then compound 3.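

On the amide-type nitrogen, 3-hydroxypyridin-2-yl in place of 2-fluorophenyl gives a 6.7-fold higher number from compound 2 to compound 3 (0.83 log units; beyond the scatter) in this assay, so a change at this place can shift the number well beyond the scatter. The step comes with no change in the count of heavy atoms. Nothing measured here accounts for its size. The compounds shown leave open whether the ring nitrogen or the hydroxyl carries the step, since both enter together. Plain pyridin-2-yl or 2-hydroxyphenyl on this nitrogen would separate the two.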